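A few compounds are considered here, and "the series" means these few. Any claim that something is new, unique, unknown or untested is made for them only; others in the source may bear on it.

Measured so far:
compound 1, `Nc1nc(N/N=C/c2cncs2)nc2c1ncn2[C@@H]1O[C@H](CO)[C@@H](O)[C@H]1O`, 22 nM
compound 2, `CC(/C=N/Nc1nc(N)c2ncn([C@@H]3O[C@H](CO)[C@@H](O)[C@H]3O)c2n1)Cc1ccc(C(C)C)cc1`, 9500 nM

In an assay on CHO-K1 cells for displacement of a labelled ligand from adenosine receptor A1 (Homo sapiens), read by scintillation counting, with a stated time of 60 min (on this read-out higher numbers stand for weaker inhibition and lower numbers for stronger inhibition), compound 1 gives the lower of the two numbers. Compound 2 gives a number far higher than that of compound 1, a gap well beyond the usual scatter; the two structures differ in more than one place, so only the two values themselves can be compared. The next compound is compound 3, `Nc1nc(N/N=C/C2CCCC2)nc2c1ncn2[C@@H]1O[C@H](CO)[C@@H](O)[C@H]1O`, which has not yet been measured. It differs from compound 1 in a single place: cyclopentyl in place of 1,3-thiazol-5-yl on a carbon with a double bond to nitrogen. Among the compounds with values here, compound 2, the only other measured compound, carries a non-aromatic hydrocarbon group at the same carbon and gives 9500 nM, which points to a move toward weaker inhibition. Compound 3 is therefore expected to give 120 nM, within a range of 25 nM to 600 nM, a step from compound 1 to compound 3 estimated at a 5.5-fold higher number from compound 1 to compound 3 (0.74 log units; beyond the scatter), beyond the scatter.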

Compound 3, inhibition constant: 5.6 nM
Beside the measured number, compound 3's estimate is 21-fold (1.33 log units) above it; the measured number lies below the stated range.
By their numbers in this assay, from the lowest: compound 3; then compound 1; then compound 2.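

In this assay, replacing 1,3-thiazol-5-yl with cyclopentyl gives a 3.9-fold lower number from compound 1 to compound 3 (0.59 log units; beyond the scatter). For this pair, a five-membered aromatic ring with hetero atoms is therefore not needed on this carbon with a double bond to nitrogen: a non-aromatic ring of carbon only, with no hydrogen-bond acceptors, gives the lower number. No evidence is available to explain this step.

Compound 2 differs from both compounds in more than one place, so it does not show how its group alone acts at this carbon. On these data alone, it remains open whether a cyclohexyl ring, an open pentyl chain or a cyclopentyl ring bearing an amine would keep a number as low as that of compound 3.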